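Removing the oxan-2-yl group from compound 3

The source may hold more compounds than are shown below. What is called first, only, known or untested is meant among the compounds shown, and "the series" means these compounds.

Measured in a functional assay on MIA PaCa-2 cells (Homo sapiens) for antiproliferative activity, read by resazurin assay, with a stated time of 70 h; on this read-out lower numbers stand for stronger inhibition and higher numbers for weaker inhibition:
compound 1 `[O-][S+](CC#Cc1ccccc1C#CCCCCO)c1c(F)c(F)c(F)c(F)c1F`: > 10000 nM (a limit)
compound 2 `[O-][S+](CC#Cc1ccccc1)c1c(F)c(F)c(F)c(F)c1F`: 7800 nM
compound 3 `[O-][S+](CC#Cc1cccnc1C#CCOC1CCCCO1)c1c(F)c(F)c(F)c(F)c1F`: 1000 nM

Compound 3, at 1000 nM, holds the lowest number, and its nearest neighbour is compound 2 at 7800 nM. Compound 4 `[O-][S+](CC#Cc1cccnc1C#CCO)c1c(F)c(F)c(F)c(F)c1F` differs from compound 3 by hydrogen in place of oxan-2-yl on an oxygen on a saturated carbon, which turns 3-((oxan-2-yl)oxy)prop-1-yn-1-yl into 3-hydroxyprop-1-yn-1-yl. Among the measured compounds shown here, the only measured step, an at least 1.2-fold lower number from compound 1 to compound 2 (0.10 log units; that floor lies within the scatter), concerns a different change and bears on this one only loosely. Compound 1 also carries a hydroxy group, and its > 10000 nM is a limit. A modest rise is therefore expected in this assay, an estimated 2.0-fold higher number from compound 3 to compound 4 (0.30 log units; within the scatter). Compound 4 is estimated at 2000 nM, with an expected range of 600 nM to 7000 nM.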

Compound 4, half-maximal inhibitory concentration: 800 nM
Compound 4: middle estimate off by 2.5-fold (0.40 log units), on the high side; the range from low to high includes it.
By their numbers in this assay, from the lowest: compounds 4 and 3 (each within the scatter of the next); then compound 2. At a limit, above all of these: compound 1.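

In this assay, the oxan-2-yl group on this oxygen on a saturated carbon can go without a change beyond the scatter: a 1.3-fold lower number from compound 3 to compound 4 (0.10 log units; within the scatter). Among the compounds shown here, this is the first measured step at this place, and it shows that 3-((oxan-2-yl)oxy)prop-1-yn-1-yl and 3-hydroxyprop-1-yn-1-yl are not told apart by this read-out, even though a six-membered non-aromatic ring leaves. Nothing measured here gives a reason for this result. Going by these compounds, it remains open whether an amine, a carboxylic acid or a longer chain in place of the hydroxy group would move the number beyond the scatter.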